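The compounds below may be only part of what the source reports. "The series", "measured", "known", "first", "only" and "open" are said of these compounds alone.

Compound 1 `COC(=O)c1ccc(C(=O)Nc2cccc3c2N(S(=O)(=O)c2ccc(OC)cc2)CC3)cc1`: 376 nM
Compound 2 `COc1ccc(S(=O)(=O)N2CCc3cccc(NC(=O)Oc4ccccc4)c32)cc1`: > 10000 nM

In a functional assay on KB cells (Homo sapiens) for cytotoxicity (on this read-out higher numbers stand for weaker inhibition and lower numbers for stronger inhibition), compound 1 gives 376 nM. In this assay, compound 2 gives > 10000 nM, and this is a limit of the assay, not a number. Compound 2 therefore has no exact position, and only the limit shows where it stands: the limit of > 10000 nM in this assay, at which 1 of the 2 values shown sits.

Compound 3 `COc1ccc(S(=O)(=O)N2CCc3cccc(NC(=O)c4ccncc4)c32)cc1` changes compound 2 in one place: pyridin-4-yl in place of phenoxy on a carbonyl carbon. In words, pyridin-4-yl stands in place of phenoxy on a carbonyl carbon.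

Among the compounds with values here, one measured step bears on this change: an at least 26-fold higher number from compound 1 to compound 2 (1.42 log units; beyond the scatter). That step is large and beyond the scatter, and it introduces the same phenoxy that compound 3 gives up. Compound 3 instead resembles compound 1, with a six-membered aromatic ring in that place, although pyridin-4-yl itself has not been measured here. A large move towards stronger inhibition is therefore expected, reversing the earlier step.

The expected change is an at least 100-fold lower number from compound 2 to compound 3 (2.00 log units; beyond the scatter).

For compound 3, the estimated value is 100 nM, with an expected range from 10 nM to 1000 nM.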

Compound 3, half-maximal inhibitory concentration: 9.6 nM
Compound 3: middle estimate off by 10-fold (1.02 log units), on the high side; measured number below the stated range.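

In this assay, replacing phenoxy with pyridin-4-yl on this carbonyl carbon gives a very large gain in inhibition (an at least 1000-fold lower number from compound 2 to compound 3 (3.01 log units; beyond the scatter)). The change from 4-(methoxycarbonyl)phenyl to pyridin-4-yl shows that the choice among six-membered aromatic rings also matters, as it too gives a large shift towards stronger inhibition (a 39-fold lower number from compound 1 to compound 3 (1.59 log units; beyond the scatter)). Compound 2 sits at a limit of the assay, so the step from it gives only a minimum size, and its full size remains unknown: the limit of > 10000 nM in this assay, at which 1 of the 3 values shown sits.

The compounds shown leave open whether the ring nitrogen of pyridin-4-yl is what separates compound 3 from compound 1, or whether the loss of the methoxycarbonyl group could account for the difference, a question that plain phenyl would help to answer. They also leave open how pyridin-3-yl, pyridin-2-yl or a saturated ring such as piperidin-4-yl would behave on the same carbonyl carbon, and so how narrowly the strong inhibition of compound 3 depends on this exact group.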